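The compounds below may be only part of what the source reports. "The series", "measured", "known", "first", "only" and "open" are said of these compounds alone.

Compounds measured so far in a functional assay on A549 cells (Homo sapiens) for antiproliferative activity, read by MTT assay; a lower number here means a stronger inhibitor, a higher number a weaker inhibitor:
- compound 1 `COc1cc2c(Oc3ccc(NC(=O)Nc4ccccc4Cl)cc3)ccnc2cc1OCCCCCCC(=O)NO` gives 1910 nM
- compound 2 `COc1cc2c(Oc3ccc(NC(=O)Nc4cccc(C)c4)cc3)ccnc2cc1OCCCCCCC(=O)NO` gives 2010 nM
- compound 3 `COc1cc2c(Oc3ccc(NC(=O)Nc4ccc(OC(F)(F)F)cc4)cc3)ccnc2cc1OCCCCCCC(=O)NO` gives 3130 nM

Compound 3 (3130 nM) stands level with the other two compounds, since its steps to both lie within the scatter. The three values therefore cannot be ranked. The next compound, compound 4 (`COc1cc2c(Oc3ccc(NC(=O)Nc4ccccc4C(F)(F)F)cc3)ccnc2cc1OCCCCCCC(=O)NO`), differs from compound 3 in one place: 2-(trifluoromethyl)phenyl in place of 4-(trifluoromethoxy)phenyl on an amide-type nitrogen. In words, 2-(trifluoromethyl)phenyl comes in place of 4-(trifluoromethoxy)phenyl on an amide-type nitrogen.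

All three measured steps are swaps at this same place. They are a 1.6-fold higher number from compound 1 to compound 3 (0.21 log units; within the scatter), a 1.6-fold higher number from compound 2 to compound 3 (0.19 log units; within the scatter) and a 1.1-fold higher number from compound 1 to compound 2 (0.02 log units; within the scatter), and each stays within the scatter. The first of these bears most closely, as it also joins 4-(trifluoromethoxy)phenyl to a 2-substituted phenyl, the 2-chlorophenyl of compound 1. None of the three shows that this place moves the number in this assay, so no step beyond the scatter is expected, in either direction. The estimated step is a 1.4-fold lower number from compound 3 to compound 4 (0.13 log units; within the scatter) and it is expected to remain within the scatter. For compound 4 the expected value is 2300 nM and the expected range runs from 1100 nM to 4800 nM as an estimate.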

Compound 4, half-maximal inhibitory concentration: 5280 nM
Beside the measured number, compound 4's estimate is 2.3-fold (0.36 log units) below it; the measured number lies above the stated range.
By their numbers in this assay, from the lowest: compounds 1, 2, 3 and 4 (each within the scatter of the next, the first and the last beyond it).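

In this assay, within the data shown here, this place on the amide-type nitrogen now shows a change beyond the scatter, which none of the earlier steps did: 2-(trifluoromethyl)phenyl gives a 2.6-fold higher number from compound 2 to compound 4 (0.42 log units; beyond the scatter) and a 2.8-fold higher number from compound 1 to compound 4 (0.44 log units; beyond the scatter), though the step from 4-(trifluoromethoxy)phenyl remains small, at a 1.7-fold higher number from compound 3 to compound 4 (0.23 log units; within the scatter). The step from compound 1 also shows that a 2-substituted phenyl does not by itself fix the number here, since exchanging chloro for trifluoromethyl on that aromatic carbon is enough to carry the value beyond the scatter, while compound 3 stays within the scatter of compounds 1, 2 and 4 alike. No measurement is available that accounts for this shift.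

The compounds shown leave open whether the higher number follows trifluoromethyl specifically, as they offer no comparison with an unsubstituted phenyl, a 2-methylphenyl or a 2-methoxyphenyl at this place. As far as these compounds go, they also share one core and one chain ending in the N-hydroxy amide, so whether these steps would hold with a shorter chain or a carboxylic acid at that end remains unknown.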